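Compound 2 to compound 4: exposure notes

A few compounds are considered here, and "the series" means these few. Any claim that something is new, unique, unknown or untested is made for them only; others in the source may bear on it.

Measured in an ADME assay on the whole organism for pharmacokinetics, with Rattus norvegicus as the target, at a dose of 5 mg/kg by the oral route; on this read-out lower numbers stand for lower exposure and higher numbers for higher exposure at the dose given
compound 1 `CC(C)(O)c1ccc(-c2cnc3c(n2)N(CC2CCOCC2)C(=O)CN3)cn1`: 3800 ng.h/mL
compound 2 `CO[C@H]1CC[C@@H](CN2CC(=O)Nc3ncc(-c4ccc(C(C)(C)O)nc4)nc32)CC1`: "not determined" (no result reported)
compound 3 `CO[C@H]1CC[C@H](N2C(=O)CNc3ncc(-c4ccc(C(C)(C)O)nc4)nc32)CC1`: 10300 ng.h/mL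

Compound 2 has no number in this assay so the step to compound 4 `CO[C@H]1CC[C@H](N2CC(=O)Nc3ncc(-c4ccc(C(C)(C)O)nc4)nc32)CC1` has no measured starting point. The change is 4-methoxycyclohexyl in place of (4-methoxycyclohexyl)methyl on a nitrogen on an aromatic ring in a ring and it puts 4-methoxycyclohexyl in place of (4-methoxycyclohexyl)methyl on a nitrogen on an aromatic ring in a ring. The nearest measured step is a 2.7-fold higher number from compound 1 to compound 3 (0.43 log units; beyond the scatter) but it sits on an amide-type nitrogen and also changes the ring, so it carries over only loosely. A modest rise in this assay is therefore expected for this change, with wide uncertainty. For compound 4 the expected value is 6000 ng.h/mL with an estimated range from 2000 ng.h/mL to 18000 ng.h/mL in this measurement.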

Compound 4, area under the concentration-time curve: 35800 ng.h/mL
Beside the measured number, compound 4's estimate is 6.0-fold (0.78 log units) below it, outside the stated range (above it).
By their numbers in this assay, from the lowest: compound 1; then compound 3; then compound 4.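

With no single number for compound 2, the step to compound 4 cannot be read. The compounds shown leave open what 4-methoxycyclohexyl in place of (4-methoxycyclohexyl)methyl does to exposure. No evidence bears on this result.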